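The source may hold more compounds than are shown below. What is called first, only, known or untested is meant among the compounds shown, and "the series" means these compounds.

In a physicochemical assay for solubility, in phosphate buffer, at pH 7.4 (a lower number here means a less soluble compound, a higher number a more soluble compound), compound 3 (`CC(=O)N[C@@H]1CCC[C@H](C(=O)Nc2cc(-c3cnn4c3OCCC4)c(Cl)cn2)C1`) gives 110000 nM, within the scatter of compound 1 (`CC(=O)N[C@@H]1CCC[C@H](C(=O)Nc2cc(-c3cnn4c3COCC4)c(Cl)cn2)C1`) at 220000 nM, while compound 2 (`CC(=O)N[C@@H]1CCC[C@H](C(=O)Nc2cc(-c3cnn4c3CN(C)CC4)c(Cl)cn2)C1`) gives a clearly higher 870000 nM. Compound 4 (`CC(=O)N[C@@H]1CCC[C@H](C(=O)Nc2cc(-c3cnc4n3CC(C)(C)C4)c(Cl)cn2)C1`) changes the group on the same aromatic carbon, opposite the ring nitrogen: a group of 10 heavy atoms (8 carbon, 2 nitrogen; one five-membered non-aromatic ring with 1 hetero atom, one five-membered aromatic ring with 2 hetero atoms) in place of a group of 9 heavy atoms (6 carbon, 2 nitrogen, 1 oxygen; one five-membered aromatic ring with 2 hetero atoms, one six-membered non-aromatic ring with 2 hetero atoms), on an aromatic carbon. Three measured swaps at this carbon bear on the change. They are a 2.0-fold lower number from compound 1 to compound 3 (0.30 log units; within the scatter), a 4.0-fold higher number from compound 1 to compound 2 (0.60 log units; beyond the scatter) and a 7.9-fold lower number from compound 2 to compound 3 (0.90 log units; beyond the scatter). Swaps here have thus ranged from nothing measurable to modest steps, and none of them introduces the new ring pair, so no direction is clear. The expected result is no change beyond the scatter, although a modest step either way remains possible. The estimated step is a 1.4-fold higher number from compound 3 to compound 4 (0.13 log units; within the scatter). For compound 4 the estimated value is 150000 nM, with an expected range of 45000 nM to 500000 nM.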

Compound 4, solubility: 280000 nM
Compound 4: middle estimate off by 1.9-fold (0.27 log units), on the low side, and the stated range covers the measured number.
By their numbers in this assay, from the lowest: compounds 3, 1 and 4 (each within the scatter of the next, the first and the last beyond it); then compound 2.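

Putting the new ring pair on this carbon gives a 2.5-fold higher number from compound 3 to compound 4 (0.41 log units; beyond the scatter) in this assay but only a 1.3-fold higher number from compound 1 to compound 4 (0.10 log units; within the scatter) here. A group without a six-membered non-aromatic ring therefore still falls inside the span already seen at this position. Compound 2 keeps the highest number, with a 3.1-fold lower number from compound 2 to compound 4 (0.49 log units; beyond the scatter) as the step down.

As far as these compounds go, whether a carboxylic acid or a longer chain on this carbon would reach beyond that span remains open. No measurement shown explains any of these steps.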